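This account rests on a few compounds, and the source may have more. Where it says the series, first, only, none or still open, it means among the compounds named here.

Within the data shown here, in a functional assay on U-937 cells (Homo sapiens) for inhibition, read by MTT assay, with a stated time of 48 h (on this read-out higher numbers stand for weaker inhibition and lower numbers for stronger inhibition), compound 1 `O=C(CCCOc1no[n+]([O-])c1S(=O)(=O)c1ccccc1)NO` gives 3300 nM, the lower of the two numbers measured so far. Among the measured compounds shown here, the only other measured compound, compound 2 `O=C(CCCCCCOc1no[n+]([O-])c1S(=O)(=O)c1ccccc1)NO`, gives 9930 nM. Next comes compound 3 `O=C(/C=C/COc1no[n+]([O-])c1S(=O)(=O)c1ccccc1)NO`, which keeps the core of compound 1 and changes only the chain: 2-(hydroxycarbamoyl)ethenyl in place of 2-(hydroxycarbamoyl)ethyl on a saturated chain carbon bound to an oxygen on an aromatic ring. Put another way, 3-(hydroxycarbamoyl)propyl becomes 3-(hydroxycarbamoyl)prop-2-en-1-yl. For the measured compounds named here, the one measured step, a 3.0-fold higher number from compound 1 to compound 2 (0.48 log units; beyond the scatter), bears on this only loosely: it lengthens the chain and adds no double bond. Going by the values given here, no measurement yet shows what a double bond does here. Among the compounds with values here, with only that modest step as a guide, no change beyond the scatter is expected in this assay, and no direction can be favoured. The expected result is a 1.0-fold lower number from compound 1 to compound 3 (0.01 log units; within the scatter). For compound 3 the estimated value is 3200 nM, with an expected range of 1100 nM to 9000 nM.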

Compound 3, half-maximal inhibitory concentration: 48000 nM
The estimate for compound 3 lay 15-fold (1.18 log units) below the measured number, and the stated range ends below it.
By their numbers in this assay, from the lowest: compound 1; then compound 2; then compound 3.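

In this assay, the chain turns out to matter for more than its length: 3-(hydroxycarbamoyl)prop-2-en-1-yl in place of 3-(hydroxycarbamoyl)propyl keeps the same count of heavy atoms, yet gives a 15-fold higher number from compound 1 to compound 3 (1.16 log units; beyond the scatter). That is a larger step than the one from lengthening the chain, a 3.0-fold higher number from compound 1 to compound 2 (0.48 log units; beyond the scatter), so among these compounds a double bond in the chain weakens inhibition more than the longer chain does. Nothing available explains this loss of inhibition.

The compounds shown leave open how a chain with a triple bond, or with the double bond elsewhere along it, would read in this assay. They also leave open whether the chain's effect would persist with a carboxylic acid in place of the hydroxycarbamoyl end.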